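This account rests on a few compounds, and the source may have more. Where it says the series, first, only, none or still open, it means among the compounds named here.

Of the compounds shown here, two with a shared core have been measured so far. Compound 1 `CCCOc1ccc(-c2nc3cc(C(F)(F)F)ccc3[nH]2)cc1` carries a propoxy group, while compound 2 `CCOc1ccccc1-c1nc2cc([N+](=O)[O-])ccc2[nH]1` carries an ethoxy group and a nitro group on different parts of the molecule. In a functional assay on aorta (Rattus norvegicus, strain Wistar) for inhibition, with a stated time of 60 min (a higher number here means a larger maximal response, a lower number a smaller maximal response), compound 1 gives 51%, the lower of the two numbers; in this assay compound 2 gives 84.8%, a gap that lies beyond the usual scatter. Since these two compounds differ in more than one place, their values show only that both reach a clear response, with compound 2 reaching the larger one.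

Compound 3 `CN(C)c1ccc(-c2nc3cc(C(F)(F)F)ccc3[nH]2)cc1` has not yet been measured. It differs from compound 1 in a single place: dimethylamino in place of propoxy on an aromatic carbon. Among the compounds with values here, no measured pair shows this exact change, so the size of the step cannot be read from the data. Given only the value of compound 1 51%, a step of a number 4 percentage points higher from compound 1 to compound 3 (within the scatter) is expected, which stays within the scatter. Compound 3 is therefore expected to give about 55%, within a range from 35% to 75%.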

Compound 3, largest response reached (Emax), in percent of the reference or control that the assay uses: 63.2%
For compound 3 the middle estimate is 8.2 percentage points below the measured one, within the range that was stated.
By their numbers in this assay, from the lowest: compound 1; then compound 3; then compound 2.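

In this assay, placing dimethylamino instead of propoxy on this aromatic carbon, para to a large group, gives a number 12.2 percentage points higher from compound 1 to compound 3 (beyond the scatter), a modest change. Within the data shown here, this is the only comparison so far in which a single place differs, so it shows that the maximal response depends on the group at this position, even though the core of compound 1 stays the same. The two groups have the same counts of hydrogen-bond donors and acceptors, and nothing measured here explains the step.

Going by these compounds, it remains open how a carboxylic acid, a primary amine or a longer alkoxy chain at this position would compare with propoxy and dimethylamino. One step also cannot show whether this swap would shift the response in the same direction on a differently substituted core.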